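Diaryl urea amides: ring substitution swap on the urea

The source may report more compounds than this note shows. Statements on the series, on what has been measured and on what is new or still open speak of the compounds shown alone.

Measured so far in a functional assay on MX1 cells (Homo sapiens) for inhibition, read by MTT assay, with a stated time of 120 h; a higher number here means a weaker inhibitor, a lower number a stronger inhibitor:
compound 1, `CC(NC(=O)/C=C/c1ccc(NC(=O)Nc2ccc(Cl)c(C(F)(F)F)c2)cc1)c1ccccc1`, gives 3130 nM;
compound 2, `CC(NC(=O)/C=C/Oc1ccc(NC(=O)Nc2cc(C(F)(F)F)ccc2Cl)cc1)c1ccccc1`, gives 16100 nM;
compound 3, `CC(NC(=O)/C=C/Oc1ccc(NC(=O)Nc2ccc(Cl)c(C(F)(F)F)c2)cc1)c1ccccc1`, gives 13700 nM.

Compound 1 has the lowest number of the three, and both compound 2 and compound 3 lie beyond the scatter from it. The difference between the core of compound 1 and the core of compound 3 is not broken down here. Within the core shared by compound 2 and compound 3, the change 2-chloro-5-(trifluoromethyl)phenyl in place of 4-chloro-3-(trifluoromethyl)phenyl on an amide-type nitrogen gave a 1.2-fold higher number from compound 3 to compound 2 (0.07 log units; within the scatter) in this assay.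

Compound 4, `CC(NC(=O)/C=C/c1ccc(NC(=O)Nc2cc(C(F)(F)F)ccc2Cl)cc1)c1ccccc1`, is not yet measured. It differs from compound 1 by 2-chloro-5-(trifluoromethyl)phenyl in place of 4-chloro-3-(trifluoromethyl)phenyl on an amide-type nitrogen, the same change that was made from compound 3 to compound 2, at a place described in the same words. The step is expected to be a 1.2-fold higher number from compound 1 to compound 4 (0.08 log units; within the scatter), small like the earlier one, because the earlier change gave a 1.2-fold higher number from compound 3 to compound 2 (0.07 log units; within the scatter). Among the compounds with values here, compound 4 is therefore estimated at 3800 nM, between 1700 nM and 8500 nM, since only a single prior instance of this change supports the expectation.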

Compound 4, half-maximal inhibitory concentration: 1890 nM
Beside the measured number, compound 4's estimate is 2.0-fold (0.30 log units) above it; the measured number falls inside the stated range.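

In this assay, 2-chloro-5-(trifluoromethyl)phenyl in place of 4-chloro-3-(trifluoromethyl)phenyl on an amide-type nitrogen gave a 1.7-fold lower number from compound 1 to compound 4 (0.22 log units; within the scatter). Set beside its earlier instance, the change shows no detectable dependence on the core: the same change on two cores in this assay, a 1.2-fold higher number (0.07 log units; within the scatter) from compound 3 to compound 2 and a 1.7-fold lower number (0.22 log units; within the scatter) from compound 1 to compound 4, 1.9-fold (0.29 log units) apart, within the scatter of two such steps. The step therefore stays small on both cores and the two substituted phenyl groups cannot be told apart here, but this does not establish a consistent direction for the step, and two cores cannot show that it would stay small on a third.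

The compounds shown leave open whether a nitrile in place of trifluoromethyl, or a fluorine in place of chlorine, would also leave the number within the scatter on these cores. They also leave open how the change behaves on a core carrying a carboxylic acid or an amine at the amide end, and whether its small size extends beyond this single assay.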